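Mirror-image hydroxypyrrolidine amide within a series of limit values

The source may report more compounds than this note shows. Statements on the series, on what has been measured and on what is new or still open speak of the compounds shown alone.

Compound 3, `COc1ccc(C#Cc2ccc(C(=O)N3CC4CCC(O)C4C3)cc2)cc1`, is one of three related amides tested in a functional assay on HEK293 cells for negative allosteric modulation of metabotropic glutamate receptor 2 (Rattus norvegicus), read by calcium flux, with a stated time of 2.5 min; on this read-out higher numbers stand for weaker inhibition and lower numbers for stronger inhibition. In this assay compound 3 gives only a limit, > 30000 nM. Compound 1, `COc1ccc(C#Cc2ccc(C(=O)N3CC[C@@H](O)C3)cc2)cc1`, likewise gives only a limit, > 30000 nM. Compound 2, `COc1ccc(C#Cc2ccc(C(=O)N3CC4CCC(=O)C4C3)cc2)cc1`, also reaches only a limit, > 30000 nM. All three values sit at the same limit, as the limit of > 30000 nM in this assay, at which 3 of the 3 values shown sit, records, so none of the steps among them can be read: a step that the two limits leave unreadable from compound 1 to compound 3, a step that the two limits leave unreadable from compound 2 to compound 3 and a step that the two limits leave unreadable from compound 1 to compound 2 are all of unreadable size. Compound 4, `COc1ccc(C#Cc2ccc(C(=O)N3CC[C@H](O)C3)cc2)cc1`, differs from compound 3 by a group of 6 heavy atoms (4 carbon, 1 nitrogen, 1 oxygen; one five-membered non-aromatic ring with 1 hetero atom) in place of a group of 9 heavy atoms (7 carbon, 1 nitrogen, 1 oxygen; one five-membered non-aromatic ring of carbon only, one five-membered non-aromatic ring with 1 hetero atom), on a carbonyl carbon. Going by the values given here, the only measured steps that bear on this change are the unreadable ones just named, and compound 1 already carries a 3-hydroxypyrrolidin-1-yl group on the same carbonyl carbon while sitting at the limit with > 30000 nM. The step that the limit leaves unreadable from compound 3 to compound 4 is therefore expected to be none beyond the scatter, with the result most likely once more a limit. Compound 4 is expected to give about 40000 nM, within 15000 nM to 100000 nM.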

Compound 4, half-maximal inhibitory concentration: > 30000 nM
Compound 4: no number, only a limit (the forecaster's own chance of this, stated with the estimate: 85%); the middle value is on the limit's open side.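

Compound 4 also gives only a limit, so none of its steps to compound 1, compound 2 or compound 3 can be read: the limit of > 30000 nM in this assay, at which 4 of the 4 values shown sit.

The compounds shown leave open how strongly any of them inhibits, and whether the configuration as drawn affects inhibition at all: the fact that compounds 1 and 4 differ only in the configuration as drawn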